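This account rests on a few compounds, and the source may have more. Where it says the series, first, only, none or still open, it means among the compounds named here.

Measured compounds in the series:

compound 1 `c1cnc2c(c1)CCC[C@@H]2N(CC1CC1)C[C@H]1Cc2c(cccc2N2CCNCC2)CN1` — 82.1%
compound 2 `c1cnc2c(c1)CCC[C@@H]2N(CC1CCCCC1)C[C@H]1Cc2c(cccc2N2CCNCC2)CN1` — 81.6%
compound 3 `CN1CCN(c2cccc3c2C[C@H](CN(C)[C@H]2CCCc4cccnc42)N(C)C3)CC1` — 83.3%

In an ADME assay on microsomes from liver (Homo sapiens) for metabolic stability, read by LC-MS, with a stated time of 10 min (on this read-out higher numbers stand for a more stable compound and lower numbers for a less stable compound), compound 2 gives 81.6%, the lowest of the three numbers, but its nearest neighbour compound 1 sits only a number 0.5 percentage points lower from compound 1 to compound 2 (within the scatter) away, and compound 3, the furthest, lies within the scatter of it as well. On the numbers shown, the three compounds are indistinguishable in this assay.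

The next compound, compound 4 `FC1(F)CCC(CN(C[C@H]2Cc3c(cccc3N3CCNCC3)CN2)[C@H]2CCCc3cccnc32)CC1`, differs from compound 2 in one place: 4,4-difluorocyclohexyl in place of cyclohexyl on a saturated chain carbon bound to an amine nitrogen. For the measured compounds named here, the only measured step that bears on this position is the one from compound 1 to compound 2, where cyclohexyl replaced cyclopropyl on the same saturated chain carbon bound to an amine nitrogen; it gave a number 0.5 percentage points lower from compound 1 to compound 2 (within the scatter). Going by the values given here, no measured pair speaks to fluorine on that ring. Given that the one comparable change at this position left this assay unmoved, the step from compound 2 to compound 4 is expected to be a number 0.6 percentage points lower from compound 2 to compound 4 (within the scatter), none beyond the scatter.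

Compound 4 is therefore estimated at 81% in this assay, with a range from 70% to 91%.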

Compound 4, percent of the compound remaining: 68.6%
For compound 4 the middle estimate is 12.4 percentage points above the measured one; measured number outside the range, below it.
By their numbers in this assay, from the lowest: compound 4; then compounds 2, 1 and 3 (each within the scatter of the next).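

In this assay this position, on a saturated chain carbon bound to an amine nitrogen, proves sensitive to the substituent: the read-out gives a number 13 percentage points lower from compound 2 to compound 4 (beyond the scatter) for 4,4-difluorocyclohexyl in place of cyclohexyl, whereas the earlier change of cyclopropyl to cyclohexyl gave only a number 0.5 percentage points lower from compound 1 to compound 2 (within the scatter) and showed no response at this position. The replacement of cyclopropyl by 4,4-difluorocyclohexyl gives a similar result, a number 13.5 percentage points lower from compound 1 to compound 4 (beyond the scatter), so among the compounds shown the fall appears only with the 4,4-difluorocyclohexyl group and not with the change from the small ring to the larger carbon-only ring. Nothing in the data shown offers an explanation for this fall.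

Still open, on these data alone, is whether the fall needs both fluorine atoms or would also appear with 4-fluorocyclohexyl, and whether other groups at the same place, such as 4-hydroxycyclohexyl, 4-methoxycyclohexyl or a tetrahydropyranyl ring, would behave like cyclohexyl or like 4,4-difluorocyclohexyl. Also open, as far as these compounds go, is whether an open-chain group carrying two fluorine atoms, such as 3,3-difluoropropyl, would give the same fall.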